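Replacing the 4-(1H-pyrazol-1-yl)phenyl group of compound 3

A few compounds are considered here, and "the series" means these few. Any claim that something is new, unique, unknown or untested is made for them only; others in the source may bear on it.

Of the compounds shown here, three sharing one core have been measured in a functional assay on HCT-116 cells (Homo sapiens) for inhibition, with a stated time of 72 h; a higher number here means a weaker inhibitor, a lower number a stronger inhibitor. Compound 1 `NC1CCC(Nc2nc(NCc3ccc(Br)cc3)c3ncn(C4CCCC4)c3n2)CC1` gives 790 nM, compound 2 `NC1CCC(Nc2nc(NCc3ccc(-c4ccccc4)cc3)c3ncn(C4CCCC4)c3n2)CC1` gives 745 nM, and compound 3 `NC1CCC(Nc2nc(NCc3ccc(-n4cccn4)cc3)c3ncn(C4CCCC4)c3n2)CC1` gives 320 nM, the lowest number of the three. Phenyl in place of bromo gave a 1.1-fold lower number from compound 1 to compound 2 (0.03 log units; within the scatter), which is no real change. 1H-pyrazol-1-yl in place of bromo gave a 2.5-fold lower number from compound 1 to compound 3 (0.39 log units; beyond the scatter), and the same group in place of phenyl gave a 2.3-fold lower number from compound 2 to compound 3 (0.37 log units; beyond the scatter). Both of these steps are modest.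

Compound 4 `NC1CCC(Nc2nc(NCc3ccc(-c4ccsc4)nc3)c3ncn(C4CCCC4)c3n2)CC1` has not yet been measured. It carries 6-(thiophen-3-yl)pyridin-3-yl in place of 4-(1H-pyrazol-1-yl)phenyl on a saturated chain carbon bound to a nitrogen on an aromatic ring. Among the measured compounds shown here, no measured step makes this exchange, and none introduces a thiophene or a pyridine, so the three steps bear on it only indirectly. They show the size of change seen so far when the outer group is exchanged, and they give no direction for this one. The largest, a 2.5-fold lower number from compound 1 to compound 3 (0.39 log units; beyond the scatter), is modest, so no step beyond the scatter is expected. The expected step is a 1.1-fold lower number from compound 3 to compound 4 (0.03 log units; within the scatter). In this assay the estimate for compound 4 is 300 nM, with an expected range from 110 nM to 800 nM.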

Compound 4, half-maximal inhibitory concentration: 145 nM
For compound 4 the middle estimate is 2.1-fold (0.32 log units) above the measured one; low and high end bracket the measured number.
By their numbers in this assay, from the lowest: compound 4; then compound 3; then compounds 2 and 1 (each within the scatter of the next).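

Moving from a 4-(1H-pyrazol-1-yl)phenyl to a 6-(thiophen-3-yl)pyridin-3-yl group on the saturated chain carbon gave a 2.2-fold lower number from compound 3 to compound 4 (0.34 log units; beyond the scatter) in this assay and showed that this place still responds when both aromatic rings of the outer group change together, even though the heavy-atom, donor and acceptor counts stay the same. Measured against the earlier groups, the new one gave a 5.1-fold lower number from compound 2 to compound 4 (0.71 log units; beyond the scatter) and a 5.4-fold lower number from compound 1 to compound 4 (0.74 log units; beyond the scatter), widening the range of outer-group effects beyond the largest earlier step, although each of these steps is still modest. Nothing available accounts for the gain.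

The compounds shown leave open whether the pyridine or the thiophene carries the step, as no compound here has a 6-phenylpyridin-3-yl or a 4-(thiophen-3-yl)phenyl group that would separate them. They also leave open how this place would respond to a 6-(thiophen-2-yl)pyridin-3-yl group, or to a primary amine or a carboxylic acid on the outer ring.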